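Three Compounds at the Limit and a Fourth Untested

This account rests on a few compounds, and the source may have more. Where it says the series, first, only, none or still open, it means among the compounds named here.

Compound 1 `COc1cccc(CNc2ncnc3c2ncn3C2CCCCO2)c1O` gives only a limit in an ADME assay on MCF7 cells (Homo sapiens) for cytotoxicity, with a stated time of 72 h; on this read-out higher numbers stand for weaker inhibition and lower numbers for stronger inhibition: > 100000 nM.
Compound 2 `Oc1cccc(CNc2ncnc3c2ncn3C2CCCCO2)c1O` likewise gives only a limit in this assay: > 100000 nM.
Compound 3 `COc1ccc(CNc2ncnc3c2ncn3C2CCCO2)cc1OC` also gives only a limit in this assay: > 100000 nM.

Compounds 1 and 2 differ in one place: hydrogen in place of methyl on an oxygen on an aromatic ring. The step this makes in this assay, a step that the two limits leave unreadable from compound 1 to compound 2, cannot be read, since both values are limits rather than numbers. Compounds 1 and 3 share the same atoms joined differently; how their two cores differ is not broken down here.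

Compound 4 `COc1cc(CNc2ncnc3c2ncn3C2CCCO2)ccc1O` has not yet been measured. It is related to compound 3 by the same change seen between compounds 1 and 2: hydrogen in place of methyl on an oxygen on an aromatic ring. The place of the change is described in the same words for both pairs, so this is the same change made on a different core.

What can be expected for compound 4 rests on a thin basis. Among the measured compounds shown here, all three values measured so far sit at the same point, (the limit of > 100000 nM in this assay, at which 3 of the 3 values shown sit), and the one measured step of this kind is unreadable. With compound 3 giving only a limit in this assay, compound 4 is expected to behave much the same, with an estimated step of a number no higher from compound 3 to compound 4 (the limit leaves the size open). The value estimated for compound 4 in this assay is 100000 nM, between 40000 nM and 300000 nM, and most likely it too will be reported only as a limit.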

Compound 4, half-maximal inhibitory concentration: > 100000 nM
Compound 4: a limit, no number (the forecaster's own chance of this, stated with the estimate: 85%); the middle value lies on the limit itself.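

Compound 3 and compound 4 both give only limits in this assay, and the step between them, methoxy to hydroxy, cannot be read. All the compounds shown now sit at one point: the limit of > 100000 nM in this assay, at which 4 of the 4 values shown sit. With no actual number among them, the compounds shown leave open how far methoxy to hydroxy, or the difference between the cores, shifts the cytotoxicity read-out in this assay.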